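Replacing a hydrazide with a piperidine amide

A few compounds are considered here, and "the series" means these few. Any claim that something is new, unique, unknown or untested is made for them only; others in the source may bear on it.

Of the compounds shown here, three have been measured so far. In an assay on isolated protein for inhibition of betaine--homocysteine S-methyltransferase 1 (Homo sapiens), with a stated time of 30 min, tested at 20 uM (on this read-out higher numbers stand for more inhibition at the one concentration tested (going by the name of the read-out) and lower numbers for less inhibition), compound 1 `NC(=O)C(N)CCSCCCCC(=O)O` gives 17%, compound 2 `CNC(=O)C(N)CCSCCCCC(=O)O` gives 8%, and compound 3 `NNC(=O)C(N)CCSCCCCC(=O)O` gives 28%.

Compound 3 has the highest of these three numbers, and its steps to the other two are beyond the scatter. Compound 4 `NC(CCSCCCCC(=O)O)C(=O)N1CCCCC1` has not yet been measured; it differs from compound 3 by piperidin-1-yl in place of aminoamino on a carbonyl carbon.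

Among the compounds with values here, two measured steps bear on this change. a number 9 percentage points lower from compound 1 to compound 2 (within the scatter), and a number 20 percentage points higher from compound 2 to compound 3 (beyond the scatter). Replacing the amino group on the amide-type nitrogen with a smaller carbon group already lowered the number, and the piperidin-1-yl group is larger still, so a lowering is expected: a number 18 percentage points lower from compound 3 to compound 4 (beyond the scatter). Compound 4 is therefore expected to give about 10%, between 0% and 24%.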

Compound 4, a percentage reported as inhibition, at one concentration (the size of the read-out at that concentration, not a potency): 9%
Compound 4: the middle estimate sits 1 percentage points above what was measured; the measured number falls inside the stated range.
By their numbers in this assay, from the lowest: compounds 2, 4 and 1 (each within the scatter of the next); then compound 3.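

In this assay the change to piperidin-1-yl on this carbonyl carbon shows a number 19 percentage points lower from compound 3 to compound 4 (beyond the scatter) and so removes the edge that aminoamino held. The six-membered ring reads no differently from the two smaller groups, with a number 1 percentage points higher from compound 2 to compound 4 (within the scatter) and a number 8 percentage points lower from compound 1 to compound 4 (within the scatter) as its steps, so only aminoamino stands apart at this position. No evidence at hand explains this result.

Going by these compounds, whether a pyrrolidine or morpholine ring would behave like piperidin-1-yl remains open. So does whether hydroxyamino on the same carbonyl carbon would match aminoamino.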